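A few compounds are considered here, and "the series" means these few. Any claim that something is new, unique, unknown or untested is made for them only; others in the source may bear on it.

Compound 1 `O=C(NC1CCN(Cc2ccc3ccccc3c2)CC1)c1ccccc1` gives 347 nM in an assay on isolated protein for binding affinity to melanin-concentrating hormone receptor 1 (Homo sapiens); a lower number here means a stronger inhibitor, a higher number a weaker inhibitor. Compound 2 `O=C(NC1CCN(Cc2ccc3ccccc3c2)CC1)c1ccc(F)c(F)c1` gives 18 nM in this assay, and compound 3 `O=C(NC1CCN(Cc2ccc3ccccc3c2)CC1)c1cc(F)cc(F)c1` gives 65 nM. Compound 3 therefore stands second of the three numbers: the step of a 3.6-fold higher number from compound 2 to compound 3 (0.56 log units; beyond the scatter) separates it from compound 2, and the step of a 5.3-fold lower number from compound 1 to compound 3 (0.73 log units; beyond the scatter) separates it from compound 1, while the largest step in the measured set is a 19-fold lower number from compound 1 to compound 2 (1.29 log units; beyond the scatter).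

Compound 4 `CN(C)c1cccc(C(=O)NC2CCN(Cc3ccc4ccccc4c3)CC2)c1` differs from compound 3 in one place: 3-(dimethylamino)phenyl in place of 3,5-difluorophenyl on a carbonyl carbon. Within the data shown here, no measured step involves a dimethylamino group, so none of them bears directly on this change. What the measured steps do show is that compound 1 carries phenyl where compound 3 carries 3,5-difluorophenyl, and that this difference goes with the step of a 5.3-fold lower number from compound 1 to compound 3 (0.73 log units; beyond the scatter); compound 4 sets aside the 3,5-difluorophenyl and takes on a group for which no comparison exists among these compounds. Compound 4 is thus expected to land nearer compound 1 than compound 3, which would mean the step of a 2.3-fold higher number from compound 3 to compound 4 (0.36 log units; beyond the scatter) in this assay. The estimate for compound 4 is 150 nM, with a range from 40 nM to 600 nM.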

Compound 4, inhibition constant: 125 nM
Estimate against measurement, compound 4: 1.2-fold (0.08 log units) above; measured number inside the range.
By their numbers in this assay, from the lowest: compound 2; then compounds 3 and 4 (each within the scatter of the next); then compound 1.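

Placing a dimethylamino group on the phenyl ring of compound 1 also lowers the number in this assay (a 2.8-fold lower number from compound 1 to compound 4 (0.44 log units; beyond the scatter)), so among these compounds the improvement over plain phenyl on the carbonyl carbon is not confined to the two difluorophenyl groups. Exchanging 3,5-difluorophenyl for 3-(dimethylamino)phenyl gives a 1.9-fold higher number from compound 3 to compound 4 (0.28 log units; within the scatter), which means that this assay does not separate these two groups, even though the entering group brings a nitrogen and a hydrogen-bond acceptor and both fluorines leave. The same group set against 3,4-difluorophenyl gives a 6.9-fold higher number from compound 2 to compound 4 (0.84 log units; beyond the scatter), so compound 2 keeps the lowest number of the four, and the new group does not reach what the 3,4-difluorophenyl group achieves at this place.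

Nothing available here gives a reason for any of these steps. On these data alone, it remains open whether the nitrogen of the dimethylamino group matters at all, a question that a primary amine or an isopropyl group of carbon only could address, and how a methoxy group, a nitrile or a carboxylic acid on the same ring would compare.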